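Dropping the bromo group: a small step expected

This account rests on a few compounds, and the source may have more. Where it says the series, first, only, none or still open, it means among the compounds named here.

Of the compounds shown here, two have been measured so far. Within the data shown here, compound 1 `O=C1N[C@@H](c2c[nH]c3ccccc23)CN=C1c1c[nH]c2ccccc12` and compound 2 `O=C1NC[C@@H](c2c[nH]c3cc(Br)ccc23)N=C1c1c[nH]c2ccccc12` share a core but differ in more than one place, so no single step between them is given. In an ADME assay on HCT-15 cells (Homo sapiens) for cytotoxicity (on this read-out lower numbers stand for an effect already at smaller amounts and higher numbers for an effect only at larger amounts of compound), compound 1 gives 4.1 ug/mL. In this assay compound 2 gives 4.2 ug/mL, the highest of the two numbers, yet the gap to compound 1 lies within the scatter, so the two cannot be ranked against each other. Compound 3 `O=C1NC[C@@H](c2c[nH]c3ccccc23)N=C1c1c[nH]c2ccccc12` has not yet been measured in this assay. It differs from compound 2 in one place: hydrogen in place of bromo on an aromatic carbon. Among the measured compounds shown here, no step between measured compounds is available as a guide, and the two known numbers sit close together. A step no larger than the scatter is therefore expected, estimated as no change at the digits printed from compound 2 to compound 3 (within the scatter). For compound 3 the value in this assay is estimated at 4.2 ug/mL, with a range from 2 ug/mL to 9 ug/mL.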

Compound 3, concentration for half-maximal effect: 4.79 ug/mL
Estimate against measurement, compound 3: 1.1-fold (0.06 log units) below; the measured number falls inside the stated range.
By their numbers in this assay, from the lowest: compounds 1, 2 and 3 (each within the scatter of the next).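

In this assay, among these compounds, hydrogen in place of bromo gives the first step that can be read in one place, a 1.1-fold higher number from compound 2 to compound 3 (0.06 log units; within the scatter), and this step lies within the scatter. On this aromatic carbon of the six-membered ring, meta to a fused ring and para to a fused ring, bromo and hydrogen therefore cannot be told apart on this read-out, so a bromine atom at this place is not needed for a number of this size. No measured evidence bears on what lies behind this result.

On these data alone, whether an amine, a carboxylic acid or a longer chain on the same carbon would move the number beyond the scatter remains open. Equally open, as far as these compounds go, is whether a bromo group on another carbon of this ring would give a step beyond the scatter.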